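The source may report more compounds than this note shows. Statements on the series, on what has been measured and on what is new or still open speak of the compounds shown alone.

Two pyrazoline compounds sharing one core have been tested so far. Compound 1 `CS(=O)(=O)c1ccc(C2=NN(c3ccc(C(=O)O)cc3)C(c3ccc(Cl)cc3)C2)cc1` carries a carboxylic acid on one aryl ring and a chloro on the other; in a functional assay on the whole organism for inhibition, with Rattus norvegicus as the target, read by paw edema, with a stated time of 3 h, at a dose of 50 mg/kg by the oral route (a higher number here means more inhibition at the dose given (going by the name of the read-out), a lower number less inhibition), compound 1 gives 50.4%. Compound 2 `CS(=O)(=O)c1ccc(C2=NN(c3ccc(S(N)(=O)=O)cc3)C(c3ccc(F)cc3)C2)cc1` carries a sulfonamide in place of the acid and a fluoro in place of the chloro, and in this assay compound 2 gives 65.7%, the higher of the two numbers, a gap beyond the usual scatter. Because the two compounds differ in two places at once, the share of each change in that gap cannot be told apart.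

Compound 3 `CS(=O)(=O)c1ccc(C2=NN(c3ccc(S(N)(=O)=O)cc3)C(c3ccc(Cl)cc3)C2)cc1` keeps the sulfonamide of compound 2 and differs from it by the following change: chloro in place of fluoro on an aromatic carbon. Within the data shown here, no measured pair isolates this exchange, so the expected step of a number 5.7 percentage points lower from compound 2 to compound 3 (within the scatter) from compound 2 to compound 3 is small, not beyond the scatter, with a slight lean downward. For compound 3 the estimate in this assay is 60%, with a range from 45% to 75%.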

Compound 3, a percentage reported as inhibition, in the whole organism at one dose (the size of the read-out at that dose, not a potency): 42.4%
Compound 3: the middle estimate sits 17.6 percentage points above what was measured; measured number outside the range, below it.
By their numbers in this assay, from the lowest: compounds 3 and 1 (each within the scatter of the next); then compound 2.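

With the sulfamoyl group held constant, the exchange of 4-fluorophenyl for 4-chlorophenyl can now be read on its own: in this assay, this single-atom change gives a number 23.3 percentage points lower from compound 2 to compound 3 (beyond the scatter). With chloro held constant, the exchange of carboxy for sulfamoyl gives a number 8 percentage points lower from compound 1 to compound 3 (within the scatter), so among these compounds only the halogen exchange produces a step that exceeds the usual variation, and that step has been seen only with a sulfamoyl group present. Nothing available explains why the halogen exchange has this effect.

On these data alone, whether a similar step would appear with a carboxylic acid on the other ring remains open. So does the result of putting a bromo, a methoxy or a plain hydrogen at this position, since only fluoro and chloro are shown there.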